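Swapping the pyridine of compound 1 for a pyrazole

A few compounds are considered here, and "the series" means these few. Any claim that something is new, unique, unknown or untested is made for them only; others in the source may bear on it.

Measured compounds:
compound 1 `CNC(=O)N1CCCc2ccc(NC(=O)c3ccc(-c4ccncc4)cc3)cc21` gives 88.7%
compound 2 `CNC(=O)N1CCCc2ccc(NC(=O)c3ccc(-c4ccccc4)cc3)cc21` gives 74.3%
compound 3 `CNC(=O)N1CCCc2ccc(NC(=O)c3cccc(-c4cnn(S(C)(=O)=O)c4)c3)cc21` gives 18%

In a functional assay on MV4-11 cells (Homo sapiens) for antiproliferative activity, with a stated time of 6 days, tested at 6.25 uM (a higher number here means a stronger effect of the compound at the concentration tested, a lower number a weaker effect), compound 1 stands highest of the three numbers shown. Compound 2 is its nearest neighbour, separated by a number 14.4 percentage points lower from compound 1 to compound 2 (beyond the scatter), a change of a single group at the far end of the amide. Going by the values given here, compound 3 lies furthest away; no single-place step connects it to compound 1, so its value only shows how low this series can fall when the attached ring and its position both change.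

Compound 4 `CNC(=O)N1CCCc2ccc(NC(=O)c3ccc(-c4cn[nH]c4)cc3)cc21` is the compound not yet measured. Relative to compound 1 the change is 1H-pyrazol-4-yl in place of pyridin-4-yl on an aromatic carbon.

Among the compounds with values here, the one measured step that bears on this change is the one from compound 1 to compound 2, where phenyl replaced pyridin-4-yl and the inhibition dropped by a modest but real amount. The step to compound 4 also removes pyridin-4-yl from the same aromatic carbon, but what enters is a smaller ring that still carries ring nitrogens. The expectation is therefore a decrease of similar or somewhat smaller size, that is a number 12.7 percentage points lower from compound 1 to compound 4 (beyond the scatter). Compound 4 is estimated to give 76% in this assay, expected to fall between 58% and 90%.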

Compound 4, a percentage reported as inhibition, at one concentration (the size of the read-out at that concentration, not a potency): 98.3%
Beside the measured number, compound 4's estimate is 22.3 percentage points below it; the measured number lies above the stated range.
By their numbers in this assay, from the lowest: compound 3; then compound 2; then compounds 1 and 4 (each within the scatter of the next).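

In this assay, placing 1H-pyrazol-4-yl where pyridin-4-yl stood, on the aromatic carbon para to a large group, gives a number 9.6 percentage points higher from compound 1 to compound 4 (within the scatter) and so shows that this place accepts a five-membered aromatic ring with 2 hetero atoms as well as the six-membered ring with 1 hetero atom. The new comparison with the carbon-only ring gives a number 24 percentage points higher from compound 2 to compound 4 (beyond the scatter), so among the three rings tried at this place, phenyl is the one that stands apart, with both nitrogen-bearing rings above it; compound 3 also carries a nitrogen-bearing ring and goes against this pattern on its face, but it differs from the others in more than one place and cannot be compared with them. No measurement shown here explains why the rings at this place rank as they do.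

Still open, from the compounds shown here alone, is whether a methyl group on the pyrazole nitrogen, or an amine or a carboxylic acid attached to the ring at this place, would keep the read-out at this level. A read-out at one concentration also leaves any difference in potency between compound 1 and compound 4 unresolved.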